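The source may report more compounds than this note shows. Statements on the series, on what has been measured and on what is new or still open speak of the compounds shown alone.

In a functional assay on HEL cells (Homo sapiens) for cytotoxicity (a higher number here means that more compound is tolerated, a lower number that less compound is tolerated), compound 3 (`CCCCCCCCCCc1cc2cn([C@H]3C[C@H](O)[C@@H](CO)O3)c(=O)nc2o1`) gives > 50000 nM as a limit and not a number. Compound 2 (`CCCCCCCc1cc2cn([C@H]3C[C@H](O)[C@@H](CO)O3)c(=O)nc2o1`) gives > 50000 nM as a limit too. Compound 1 (`CCCCCCc1cc2cn([C@H]3C[C@H](O)[C@@H](CO)O3)c(=O)nc2o1`) gives > 200000 nM as a limit as well. Compound 3 therefore has no numerical position in the series, and neither of the other two measured compounds offers a number to compare it with.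

Compound 4 (`C#CCCCCc1cc2cn([C@H]3C[C@H](O)[C@@H](CO)O3)c(=O)nc2o1`) has not been measured. It carries ethynyl in place of hexyl on a saturated chain carbon, four bonds along the chain from an aromatic carbon and otherwise keeps the shared core.

The measured steps that bear on this change are those along the saturated chain: a step that the two limits leave unreadable from compound 1 to compound 2 and a step that the two limits leave unreadable from compound 1 to compound 3 and a step that the two limits leave unreadable from compound 2 to compound 3 in the same assay. None gives a size, and none involves a triple bond, so they set neither a size nor a direction for the new change.

With only limits across the series, the expected step that the limit leaves unreadable from compound 3 to compound 4 in this assay is no step beyond the scatter. Compound 4 is estimated at 80000 nM with a range of 30000 nM to 200000 nM and is expected to be reported as a limit again.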

Compound 4, half-maximal cytotoxic concentration: > 200000 nM
Compound 4: no number, only a limit; the forecaster's own chance of this, stated with the estimate: 85%; middle value at least 2.5-fold (0.39 log units) from the limit.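

In this assay, among these compounds, compound 4 gives a limit and not a number, as do compound 1, compound 2 and compound 3, so no step to compound 4 can be read. The compounds shown leave open at what concentration any of them becomes cytotoxic, and whether changing the chain shifts that concentration at all.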